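Removing the Aryl Cap from an Aminoanilide in a Deacetylase Assay

A few compounds are considered here, and "the series" means these few. Any claim that something is new, unique, unknown or untested is made for them only; others in the source may bear on it.

Measured so far:
compound 1 `CCOc1cc(NC(=O)CCCCC(=O)Nc2cc(-c3ccccc3)ccc2N)cc2c1OCC([N+](=O)[O-])=C2` — 25%
compound 2 `CCOc1cc(NC(=O)CCCCC(=O)Nc2cc(-c3ccc(C)s3)ccc2N)cc2c1OCC([N+](=O)[O-])=C2` — 8%

Both compounds were tested in an assay on isolated protein for inhibition of protein deacetylase HDAC6 (Homo sapiens), read by fluorescence, with stated times of 10 min and 30 min, tested at 10 uM; on this read-out higher numbers stand for more inhibition at the one concentration tested (going by the name of the read-out) and lower numbers for less inhibition. Among the compounds with values here, compound 1 gives 25%, and compound 2 gives 8%, the lower of the two numbers, with compound 1 the only neighbour for comparison. Within the data shown here, the one measured step, a number 17 percentage points lower from compound 1 to compound 2 (beyond the scatter), came from swapping one aromatic group for another on the same aromatic carbon.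

Compound 3 `CCOc1cc(NC(=O)CCCCC(=O)Nc2ccccc2N)cc2c1OCC([N+](=O)[O-])=C2` differs from compound 2 in one place: hydrogen in place of 5-methylthiophen-2-yl on an aromatic carbon. Among the measured compounds shown here, no measured step removes the aromatic group outright, so the step of a number 17 percentage points lower from compound 1 to compound 2 (beyond the scatter) bears on this change only loosely; it shows that the identity of the group at this carbon matters within the shared core, but not what its absence does. A small shift in either direction, or none beyond the scatter, is plausible. The expected step for compound 3 is a number 4 percentage points higher from compound 2 to compound 3 (within the scatter), and compound 3 is therefore estimated at 12%, with a range from 0% to 30%.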

Compound 3, a percentage reported as inhibition, at one concentration (the size of the read-out at that concentration, not a potency): 68%
Compound 3: the middle estimate sits 56 percentage points below what was measured, outside the stated range (above it).
By their numbers in this assay, from the lowest: compound 2; then compound 1; then compound 3.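

In this assay, hydrogen in place of 5-methylthiophen-2-yl on this aromatic carbon gives a number 60 percentage points higher from compound 2 to compound 3 (beyond the scatter), and hydrogen in place of phenyl gives a number 43 percentage points higher from compound 1 to compound 3 (beyond the scatter). Within the data shown here, the earlier compounds compared only two aromatic groups at this position, whereas these steps show that removing either one changes the number far more than exchanging one for the other did, and that both aromatic groups go with a much lower number than hydrogen does. The compounds shown give no measured explanation for this rise.

Going by these compounds, it remains open whether a small group on this carbon, such as a fluorine atom, a methyl group or an amine, would keep the high number seen with hydrogen. On these data alone, it is also open whether the effect of removing the aromatic group would hold with a longer chain in the shared core.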